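Whole-organism inhibition series: bromo in place of methoxy

The source may hold more compounds than are shown below. What is called first, only, known or untested is meant among the compounds shown, and "the series" means these compounds.

Measured so far:
compound 1 `COCC1=CS(=O)(=O)c2ccccc2C1=O` — 99.9%
compound 2 `CC(C)OCC1=CS(=O)(=O)c2ccccc2C1=O` — 99.2%
compound 3 `CCC(=O)OCC1=CS(=O)(=O)c2ccccc2C1=O` — 99.5%

In a functional assay on the whole organism for inhibition, with Mus musculus as the target, at a dose of 10 mg/kg (on this read-out higher numbers stand for more inhibition at the one dose given (going by the name of the read-out) and lower numbers for less inhibition), compound 1 carries the highest of the three numbers, yet the steps of a number 0.7 percentage points lower from compound 1 to compound 2 (within the scatter) and a number 0.4 percentage points lower from compound 1 to compound 3 (within the scatter) are both within the scatter, as is a number 0.3 percentage points higher from compound 2 to compound 3 (within the scatter), so the three compounds stand together and no order among them can be read.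

Compound 4 `O=C1C(CBr)=CS(=O)(=O)c2ccccc21` is not yet measured. It differs from compound 1 as follows: bromo in place of methoxy on a saturated chain carbon bound to a double-bonded ring carbon. The measured steps all vary what sits on the oxygen on the saturated carbon; none of them removes that oxygen, so they bear on this change only in showing that the shared core has so far kept its read-out near the top whatever is carried at that position. Within the data shown here, no step among the three differs from another beyond the scatter. For compound 4 a step of a number 2.9 percentage points lower from compound 1 to compound 4 (within the scatter) is therefore expected, that is, none beyond the scatter, though with a wider range than the measured steps, since the oxygen itself is gone. Compound 4 is estimated at 97%, with a range from 85% to 100%.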

Compound 4, a percentage reported as inhibition, in the whole organism at one dose (the size of the read-out at that dose, not a potency): 92.8%
Compound 4: the middle estimate sits 4.2 percentage points above what was measured, and the stated range covers the measured number.
By their numbers in this assay, from the lowest: compounds 4, 2, 3 and 1 (each within the scatter of the next).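

The series now includes a change that removes the oxygen itself, not just what it carries, and the read-out in this assay holds: the new steps are a number 7.1 percentage points lower from compound 1 to compound 4 (within the scatter) and a number 6.7 percentage points lower from compound 3 to compound 4 (within the scatter) and also a number 6.4 percentage points lower from compound 2 to compound 4 (within the scatter). At this place, on a saturated chain carbon bound to a double-bonded ring carbon, the four compounds therefore stand together, and an oxygen there is not required for the read-out in these compounds. The data give no explanation for this result.

Going by these compounds, it remains open whether an amine, a carboxylic acid or a longer chain at this place would stand with these four compounds. With a single dose and all values close together, this assay gives no potency order among them.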